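A few compounds are considered here, and "the series" means these few. Any claim that something is new, unique, unknown or untested is made for them only; others in the source may bear on it.

Compound 3 `Cn1nc(-c2ccc(C(F)(F)F)cc2)cc1-c1nnc(SCc2cccc(Cl)c2Cl)o1` gives 60200 nM in a functional assay on MCF7 cells (Homo sapiens) for cytotoxicity, read by MTT assay, with a stated time of 24 h (on this read-out lower numbers stand for stronger inhibition and higher numbers for weaker inhibition), the highest of the three numbers measured. Compound 2 `Cn1nc(-c2ccc(C(F)(F)F)cc2)cc1-c1nnc(SCc2c(F)cccc2F)o1` gives 46200 nM, and the step of a 1.3-fold higher number from compound 2 to compound 3 (0.11 log units; within the scatter) lies within the scatter. Compound 1 `Cn1nc(-c2nnc(SCc3ccc(Cl)c(Cl)c3)o2)cc1-c1ccc(C(F)(F)F)cc1` gives 27200 nM, a number that differs from that of compound 3 by more than the scatter. The unmeasured compound 4 `Cn1nc(-c2ccc(C(F)(F)F)cc2)cc1-c1nnc(SCc2cccc([N+](=O)[O-])c2)o1` differs from compound 3 by 3-nitrophenyl in place of 2,3-dichlorophenyl on a saturated chain carbon bound to a sulfur. Within the data shown here, none of the measured steps brings in a 3-nitrophenyl group; the one measured exchange at the same position, a 1.3-fold higher number from compound 2 to compound 3 (0.11 log units; within the scatter), was small. No step beyond the scatter is therefore expected in this assay. Compound 4 is estimated at 50000 nM, in a range from 20000 nM to 125000 nM, which means an expected step of a 1.2-fold lower number from compound 3 to compound 4 (0.08 log units; within the scatter).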

Compound 4, half-maximal inhibitory concentration: > 100000 nM
Compound 4: only a limit was reported; the forecaster's own chance of this, stated with the estimate: 15%; middle value at least 2.0-fold (0.30 log units) away from the limit.
By their numbers in this assay, from the lowest: compounds 1, 2 and 3 (each within the scatter of the next, the first and the last beyond it). At a limit, above all of these: compound 4.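

Compound 4 is reported in this assay only as a limit: the limit of > 100000 nM in this assay, at which 1 of the 4 values shown sits. Among these compounds, at this place, on a saturated chain carbon bound to a sulfur, 3-nitrophenyl gives an at least 2.1-fold higher number from compound 2 to compound 4 (0.33 log units; beyond the scatter), the first exchange here to pass the scatter, so the position is not indifferent to what it carries. Against the 2,3-dichlorophenyl group, an at least 1.6-fold higher number from compound 3 to compound 4 (0.22 log units; that floor lies within the scatter) leaves the size of the change unsettled.

The compounds shown leave open how far compound 4 lies past its limit. They also leave open how an amine or a carboxylic acid on this phenyl ring would read.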